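The source may hold more compounds than are shown below. What is called first, only, known or untested is meant among the compounds shown, and "the series" means these compounds.

Working notes on the series sharing the core of compound 1 (`CCN(C1=NCCN1)c1c(Br)cccc1Br`), read in a physicochemical assay for acid dissociation. Compound 1 gives 11.1, compound 2 (`CCCCCN(C1=NCCN1)c1c(Br)cccc1Br`) gives 11, and compound 3 (`C=C(C)CCN(C1=NCCN1)c1c(Br)cccc1Br`) gives 10.9. Compound 3 therefore stands within the scatter of both other compounds, as the steps of a number 0.20 log units lower from compound 1 to compound 3 (within the scatter) and a number 0.10 log units lower from compound 2 to compound 3 (within the scatter) show.

The next structure is compound 4 (`Brc1cccc(Br)c1N(C1=NCCN1)C1CCCC1`), and the change is cyclopentyl in place of 3-methylbut-3-en-1-yl on a nitrogen on an aromatic ring. In words, this places cyclopentyl in place of 3-methylbut-3-en-1-yl on a nitrogen on an aromatic ring.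

Within the data shown here, no measured compound carries cyclopentyl, so the evidence is indirect. The three measured steps all concern a saturated chain carbon, two bonds along the chain from a nitrogen on an aromatic ring. Besides the two steps above, they include a number 0.10 log units lower from compound 1 to compound 2 (within the scatter). None of the three exceeds the scatter, although propyl and 1-methylethenyl differ from hydrogen and from each other. On the strength of these steps, including a number 0.20 log units lower from compound 1 to compound 3 (within the scatter), no step beyond the scatter is expected in this assay, and no direction can be assigned with confidence.

The estimated step is a number 0.10 log units higher from compound 3 to compound 4 (within the scatter). For compound 4 the expected value is 11, with an estimated range of 10.6 to 11.4.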

Compound 4, acid dissociation constant: 11.2
Compound 4: the middle estimate sits 0.20 log units below what was measured, within the range that was stated.
By their numbers in this assay, from the lowest: compounds 3, 2, 1 and 4 (each within the scatter of the next).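

In this assay, this position now holds a ring as well as open chains: cyclopentyl, one five-membered non-aromatic ring of carbon only, gives a number 0.30 log units higher from compound 3 to compound 4 (within the scatter) against 3-methylbut-3-en-1-yl and a number 0.20 log units higher from compound 2 to compound 4 (within the scatter) against pentyl and a number 0.10 log units higher from compound 1 to compound 4 (within the scatter) against ethyl on a nitrogen on an aromatic ring. The earlier compounds shown here covered only open chains, with or without a double bond, and the change to a ring of carbon only adds no step beyond the scatter in any of these three comparisons. Nothing available explains why the four numbers lie so close together. 

Going by these compounds, all four groups at this nitrogen are made of carbon only, so it remains open whether a chain ending in an amine or a carboxylic acid, or a ring containing oxygen such as tetrahydrofuranyl, would also stay within the scatter. Also open, on these data alone, is whether the same insensitivity to the group on this nitrogen would hold with a nitrile or a methoxy group in place of a bromine on the shared core.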